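The source may report more compounds than this note shows. Statements on the series, on what has been measured and on what is new or still open speak of the compounds shown alone.

Three analogues sharing one core have been run in an assay for inhibition of Indoleamine 2,3-dioxygenase 1 (Homo sapiens), with a stated time of 1 h, tested at 10 uM; a lower number here means less inhibition, a higher number more inhibition at the concentration tested (going by the name of the read-out). Compound 1 `Nc1cccc(CNc2cc(Br)cc3[nH]ncc23)c1` gives 31% there. Compound 2 `FC(F)(F)c1cccc(CNc2cc(Br)cc3[nH]ncc23)c1` gives 16% in this assay, a change of a number 15 percentage points lower from compound 1 to compound 2 (beyond the scatter). Compound 3 `O=C(O)Nc1cccc(CNc2cc(Br)cc3[nH]ncc23)c1` gives 57% in this assay, which places it highest of the three, with a number 26 percentage points higher from compound 1 to compound 3 (beyond the scatter) and a number 41 percentage points higher from compound 2 to compound 3 (beyond the scatter). Compound 4 `OC1CCCC(Nc2cccc(CNc3cc(Br)cc4[nH]ncc34)c2)C1` has not yet been measured. It differs from compound 3 by 3-hydroxycyclohexyl in place of carboxy on a nitrogen on an aromatic ring. The step that bears most directly on this change is the one at the same nitrogen, a number 26 percentage points higher from compound 1 to compound 3 (beyond the scatter), a modest step; the steps of a number 15 percentage points lower from compound 1 to compound 2 (beyond the scatter) and a number 41 percentage points higher from compound 2 to compound 3 (beyond the scatter) show that exchanges around this position move the number by modest to large amounts. Compound 4 is expected to give back part of that gain because a number 26 percentage points higher from compound 1 to compound 3 (beyond the scatter) was the step the carboxy brought, while the entering 3-hydroxycyclohexyl is an untested group. The expected step is a number 17 percentage points lower from compound 3 to compound 4 (beyond the scatter). Compound 4 is thus estimated at 40% in this assay, with a range from 18% to 62%.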

Compound 4, a percentage reported as inhibition, at one concentration (the size of the read-out at that concentration, not a potency): 52%
The estimate for compound 4 lay 12 percentage points below the measured number; measured number inside the range.
By their numbers in this assay, from the lowest: compound 2; then compound 1; then compounds 4 and 3 (each within the scatter of the next).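

In this assay, the 3-hydroxycyclohexyl on the nitrogen on an aromatic ring takes the place of carboxy with a number 5 percentage points lower from compound 3 to compound 4 (within the scatter), so this position accepts an all-carbon six-membered non-aromatic ring as well as carboxy. Substitution on this nitrogen is therefore not tied to carboxy for a number beyond that of the unsubstituted amino compound, with a number 21 percentage points higher from compound 1 to compound 4 (beyond the scatter) alongside a number 26 percentage points higher from compound 1 to compound 3 (beyond the scatter), and the (3-hydroxycyclohexyl)amino group also stands well clear of trifluoromethyl, with a number 36 percentage points higher from compound 2 to compound 4 (beyond the scatter). Nothing measured here explains why these two different groups give numbers within the scatter of each other.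

The compounds shown leave open whether the ring or its hydroxy carries the effect, which an unsubstituted cyclohexyl or a short chain such as ethyl on the same nitrogen could separate. With only a single tested concentration, they also leave the potency of compound 3 and compound 4 open.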